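This account rests on a few compounds, and the source may have more. Where it says the series, first, only, none or still open, it means among the compounds named here.

For the measured compounds named here, compound 2 `CCc1nc2ccccc2c(=O)n1NC(=O)Nc1ccc([N+](=O)[O-])cc1` is one of three compounds measured in a functional assay on the whole organism (strain albino) with Mus musculus as the target, at a dose of 100 mg/kg by the intraperitoneal route; on this read-out higher numbers stand for more inhibition at the one dose given (going by the name of the read-out) and lower numbers for less inhibition. In this assay compound 2 gives 41%. Compound 3 `O=C(Nc1ccc([N+](=O)[O-])cc1)Nn1c(-c2ccccc2)nc2ccccc2c1=O` gives 42%, and the step of a number 1 percentage points higher from compound 2 to compound 3 (within the scatter) lies within the scatter, so the two cannot be told apart. Compound 1 `COc1ccc(NC(=O)Nn2c(-c3ccccc3)nc3ccccc3c2=O)cc1` gives 52%, which puts compound 2 beyond the scatter below compound 1, and compound 2 therefore stands at the low end of what has been measured.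

Compound 4 `CCOc1ccc(NC(=O)Nn2c(CC)nc3ccccc3c2=O)cc1` has not been measured. It differs from compound 2 in one place: ethoxy in place of nitro on an aromatic carbon. Going by the values given here, the one measured step that bears on this change is the reverse exchange on the same position, in which a methoxy gave way to a nitro: a number 10 percentage points lower from compound 1 to compound 3 (within the scatter), a change that did not exceed the scatter. Going the other way, from nitro to an alkoxy group, a rise of similar size is expected for compound 4, but not one that clearly passes beyond the scatter; the ethoxy is not the methoxy, and no step with an ethoxy has been measured.

Compound 4 is therefore expected to give 50% in this assay, with a likely range from 38% to 62%, an expected step of a number 9 percentage points higher from compound 2 to compound 4 (within the scatter).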

Compound 4, a percentage reported as inhibition, in the whole organism at one dose (the size of the read-out at that dose, not a potency): 50%
Estimate against measurement, compound 4: no gap at the digits printed; the measured number falls inside the stated range.
By their numbers in this assay, from the lowest: compounds 2, 3, 4 and 1 (each within the scatter of the next, the first and the last beyond it).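

In this assay, the exchange of nitro for ethoxy on the aromatic carbon para to a large group, now read on the ethyl-bearing core, gives a number 9 percentage points higher from compound 2 to compound 4 (within the scatter) and so does not separate the two compounds. Until now, this position had been read only on the phenyl-bearing core and only with methoxy, where a number 10 percentage points lower from compound 1 to compound 3 (within the scatter) also stayed within the scatter, so neither the nitro-alkoxy exchange on either core nor the exchange of methoxy for ethoxy has a step beyond it; the two groups also match in their count of heavy atoms, so this exchange leaves the size of the substituent unchanged by that count. No measurement is available that would explain the result at this position.

On these data alone, what remains open is whether an amine or a carboxylic acid on this aromatic carbon would move the number beyond the scatter, since only nitro, methoxy and ethoxy are seen there. As far as these compounds go, a longer chain, such as butoxy, in place of the ethoxy is equally open, and so is the ethoxy on the phenyl-bearing core.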